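The source may hold more compounds than are shown below. What is called first, only, known or untested is meant among the compounds shown, and "the series" means these compounds.

Measured so far, in an assay on CHO cells for displacement of a labelled ligand from adenosine receptor A3 (Homo sapiens), read by scintillation counting, with a stated time of 3 h; a higher number here means a weaker inhibitor, a lower number a stronger inhibitor:

compound 1, `Nc1nc(-c2cccc(CO)c2)nc2sc(-c3ccccc3)nc12`, gives 3.7 nM;
compound 2, `N#Cc1cccc(-c2nc(N)c3nc(-c4ccccc4)sc3n2)c1`, gives 247 nM;
compound 3, `Nc1nc(-c2ccco2)nc2sc(-c3ccccc3)nc12`, gives 2.8 nM.

Compound 3 carries the lowest of the three numbers. Its nearest neighbour is compound 1, and the step of a 1.3-fold lower number from compound 1 to compound 3 (0.12 log units; within the scatter) lies within the scatter, so these two compounds cannot be ordered. The furthest is compound 2, and the step of an 88-fold lower number from compound 2 to compound 3 (1.95 log units; beyond the scatter) is large; compound 2 also stands far from compound 1, as the step of a 67-fold higher number from compound 1 to compound 2 (1.82 log units; beyond the scatter) shows.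

Compound 4, `Cc1ccc(-c2nc(N)c3nc(-c4ccccc4)sc3n2)o1`, differs from compound 3 in one place: methyl in place of hydrogen on an aromatic carbon. For the measured compounds named here, no measured step adds a methyl anywhere, so nothing speaks to this change directly. Going by the values given here, the only step that concerns the same carbon is the one from compound 1 to compound 3, which exchanged the whole group there and still stayed within the scatter, and the one large step seen, from compound 1 to compound 2, concerns a different group on a different ring. He therefore expects no step beyond the scatter for this assay, in either direction, and the estimated step of a 1.3-fold higher number from compound 3 to compound 4 (0.10 log units; within the scatter) is accordingly small. His estimate for compound 4 is 3.5 nM, with a range from 1.2 nM to 12 nM.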

Compound 4, inhibition constant: 24.9 nM
Beside the measured number, compound 4's estimate is 7.1-fold (0.85 log units) below it; measured number above the stated range.
By their numbers in this assay, from the lowest: compounds 3 and 1 (each within the scatter of the next); then compound 4; then compound 2.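

In this assay, the carbon next to the ring oxygen proves sensitive to a very small change: going from furan-2-yl to 5-methylfuran-2-yl, with only one carbon entering, gives an 8.9-fold higher number from compound 3 to compound 4 (0.95 log units; beyond the scatter). The earlier compounds shown here showed no loss at this end of the molecule among the groups that kept the number low, since furan-2-yl and 3-(hydroxymethyl)phenyl could not be ordered; 5-methylfuran-2-yl, by contrast, separates from the latter, with a 6.7-fold higher number from compound 1 to compound 4 (0.83 log units; beyond the scatter), while it remains clearly better than the 3-cyanophenyl group, with a 9.9-fold lower number from compound 2 to compound 4 (1.00 log units; beyond the scatter). So the group on this aromatic carbon gives three distinct levels in this assay, and nothing available explains why the methyl has this effect.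

Going by these compounds, whether a longer chain such as ethyl, a chlorine atom or an amine on the same furan carbon would raise the number further, leave it about where it is, or bring it back down remains open. Also open, on these data alone, is whether a methyl on one of the other furan carbons would give a step of the same size, so this single methyl step describes one carbon only.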